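Methyl on the phenol oxygen in a cytotoxicity series

The compounds below may be only part of what the source reports. "The series", "measured", "known", "first", "only" and "open" are said of these compounds alone.

Measured compounds:
Compound 1, `N#CC1=C(N)N(c2ccc(S(N)(=O)=O)cc2)C2=C(CCCC2)C1c1ccc(O)cc1`, gives 60%.
Compound 2, `COc1ccc(C2C(C#N)=C(N)N(c3ccc(S(N)(=O)=O)cc3)C3=C2CCCC3)cc1`, gives 100%.
Compound 3, `N#CC1=C(N)N(c2ccc(S(N)(=O)=O)cc2)C2=C(CCCC2)C1c1c(O)ccc2ccccc12`, gives 20%.

The three compounds were tested in a functional assay on Ehrlich cells (Mus musculus) for cytotoxicity, read by trypan blue exclusion, with a stated time of 2 h, tested at 50 ug/mL; a lower number here means a weaker effect, a higher number a stronger effect of the compound at the concentration tested. Compound 2 is the highest of the three; the step of a number 40 percentage points higher from compound 1 to compound 2 (beyond the scatter) rests on a single change, (methyl in place of hydrogen on an oxygen on an aromatic ring). Compound 3 stands lowest: a number 40 percentage points lower from compound 1 to compound 3 (beyond the scatter) and a number 80 percentage points lower from compound 2 to compound 3 (beyond the scatter) both lie beyond the scatter, and the change that sets compound 3 apart from compound 1 is 2-hydroxynaphthalen-1-yl in place of 4-hydroxyphenyl on a saturated ring carbon.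

Compound 4, `COc1ccc2ccccc2c1C1C(C#N)=C(N)N(c2ccc(S(N)(=O)=O)cc2)C2=C1CCCC2`, has not yet been measured in this assay. It differs from compound 3 by methyl in place of hydrogen on an oxygen on an aromatic ring, the same change that carries compound 1 to compound 2. The two cores are not alike, as the difference between compound 1 and compound 3 shows, so the step is placed on a different scaffold than before.

For the measured compounds named here, on the single precedent, compound 4 is expected to lie above compound 3 by a step of about a number 30 percentage points higher from compound 3 to compound 4 (beyond the scatter), because the same change gave a number 40 percentage points higher from compound 1 to compound 2 (beyond the scatter). Whether the step carries over in full on the core of compound 3 is not known from these data, so the range is kept wide. Compound 4 is estimated at 50%, between 20% and 90%.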

Compound 4, a percentage reported as activity, at one concentration (the size of the read-out at that concentration, not a potency): 10%
For compound 4 the middle estimate is 40 percentage points above the measured one, outside the stated range (below it).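

Methyl in place of hydrogen on the oxygen on an aromatic ring did not behave alike on the two cores in this assay: on the core bearing 2-hydroxynaphthalen-1-yl the step reads a number 10 percentage points lower from compound 3 to compound 4 (within the scatter), so the gain seen on the other core did not reappear. Set side by side, the two steps differ by more than repeated measurements of this kind would scatter: the same change on two cores in this assay, a number 40 percentage points higher (beyond the scatter) from compound 1 to compound 2 and a number 10 percentage points lower (within the scatter) from compound 3 to compound 4, 50 percentage points apart, beyond the scatter of two such steps. For the compounds shown here, this shows that, in this series, the effect of the change depends on the core and cannot simply be carried from one core to the other, but with only one matched pair on each core and a single read-out concentration, it does not show what lies behind the difference or how the change would behave on any further core.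

The compounds shown leave open whether the difference between the cores is special to methyl or also holds for an ethyl group or a longer chain on the same oxygen. They also leave open how either core would respond if an amine or a carboxylic acid took the place of the hydroxy group.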